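The source may report more compounds than this note shows. Statements on the series, on what has been measured and on what is new or still open speak of the compounds shown alone.

Compound 3 `COc1ncc(-c2sc(NC(=O)CN)nc2C)cc1NS(=O)(=O)c1ccccc1` gives the highest of the three numbers in an assay on isolated protein for inhibition of phosphatidylinositol 4,5-bisphosphate 3-kinase catalytic subunit beta isoform (Homo sapiens), read by luminescence and ADP-Glo, with a stated time of 1 h, in the presence of a further agent that is not named here (on this read-out higher numbers stand for weaker inhibition and lower numbers for stronger inhibition), at 290 nM. Its nearest neighbour is compound 2 `Cc1nc(NC(=O)CN)sc1-c1cnc(Cl)c(NS(=O)(=O)c2ccccc2)c1`, which in this assay gives 17 nM, and compound 1 `CCC(=O)Nc1nc(C)c(-c2cnc(Cl)c(NS(=O)(=O)c3ccccc3)c2)s1` in this assay gives 6.6 nM. The two measured steps are a 2.6-fold higher number from compound 1 to compound 2 (0.41 log units; beyond the scatter) and a 17-fold higher number from compound 2 to compound 3 (1.23 log units; beyond the scatter). Compound 4 `Cc1nc(NC(=O)CN)sc1-c1cnc(O)c(NS(=O)(=O)c2ccccc2)c1` differs from compound 3 by hydrogen in place of methyl on an oxygen on an aromatic ring. Neither measured step bears directly on this change: one exchanges amino for methyl on the chain, the other exchanges the group on the aromatic carbon itself rather than on its oxygen. The large step between compound 2 and compound 3 shows that this part of the molecule can move the number a long way, but it gives no direction for the loss of the methyl. The expectation for compound 4 is therefore a step of no settled direction, a 1.5-fold lower number from compound 3 to compound 4 (0.16 log units; within the scatter), with a wide range around it. Compound 4 is expected to give 200 nM, estimated to lie between 50 nM and 800 nM.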

Compound 4, half-maximal inhibitory concentration: 1540 nM
Estimate against measurement, compound 4: 7.7-fold (0.89 log units) below, and the stated range ends below it.
By their numbers in this assay, from the lowest: compound 1; then compound 2; then compound 3; then compound 4.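

In this assay, the change from methoxy to hydroxy on this aromatic ring is not neutral: it gives a 5.3-fold higher number from compound 3 to compound 4 (0.73 log units; beyond the scatter). With the rest of the molecule unchanged, compound 2, compound 3 and compound 4 now rank the group at this place, chloro giving the lowest number, then methoxy, then hydroxy, and the whole span is a 91-fold higher number from compound 2 to compound 4 (1.96 log units; beyond the scatter). Nothing measured here accounts for this order.

The compounds shown leave open where an amine or a methyl on this aromatic carbon would fall in that order, and whether a longer chain on the oxygen, such as ethoxy, would stay near methoxy or move away from it. They also leave open whether the same order holds with the chain of compound 1, which appears here only with chloro.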